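Replacing butyl with carboxy on compound 2

A few compounds are considered here, and "the series" means these few. Any claim that something is new, unique, unknown or untested is made for them only; others in the source may bear on it.

Of the compounds shown here, three have been measured in a functional assay on the whole organism with Rattus norvegicus as the target, at a dose of 25 mg/kg by the intravenous route; on this read-out higher numbers stand for an effect only at larger amounts of compound and lower numbers for an effect already at smaller amounts. Compound 1 (`O=C(O)c1ccc(NC(=O)c2ccc(C(=O)O)cc2)cc1`) gives 25.4 mg/kg, compound 2 (`CCCCc1ccc(C(=O)Nc2cc(C(=O)O)cc(C(=O)O)c2)cc1`) gives 12.3 mg/kg and compound 3 (`O=C(Nc1ccccc1)c1cccc(-c2nn[nH]n2)c1`) gives 4.5 mg/kg. Compound 2 thus holds the second highest number of the three, and its gaps to compound 1 and compound 3 both lie beyond the scatter. Compound 4 (`O=C(O)c1ccc(C(=O)Nc2cc(C(=O)O)cc(C(=O)O)c2)cc1`) has carboxy in place of butyl on an aromatic carbon, para to a large group: carboxy in place of butyl on an aromatic carbon. Going by the values given here, no measured pair shows this change alone, so the expectation rests on compound 1, which also carries carboxy and no butyl and gives 25.4 mg/kg. In this assay the estimate is a step toward a higher number, a 1.8-fold higher number from compound 2 to compound 4 (0.25 log units; within the scatter), close to the edge of the scatter. For compound 4 the estimated value is 22 mg/kg, with an expected range of 9 mg/kg to 50 mg/kg.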

Compound 4, dose for 50% inhibition: 2.1 mg/kg
Compound 4: the middle estimate sits 10-fold (1.02 log units) above what was measured, outside the stated range (below it).
By their numbers in this assay, from the lowest: compound 4; then compound 3; then compound 2; then compound 1.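

In this assay, carboxy in place of butyl on an aromatic carbon, para to a large group, gives a 5.9-fold lower number from compound 2 to compound 4 (0.77 log units; beyond the scatter). Going by these compounds alone, this is the first direct reading of the change, and it shows that the position accepts carboxy and that the number moves the opposite way from what compound 1 suggested. No measurement at hand speaks to the reason for this step.

Going by these compounds, whether a methyl ester or an amine in the same place would give a number close to that of compound 4 stays open. So does how a shorter chain than butyl would compare with compound 2.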